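This account rests on a few compounds, and the source may have more. Where it says the series, first, only, none or still open, it means among the compounds named here.

In a physicochemical assay for lipophilicity (on this read-out lower numbers stand for lower lipophilicity and higher numbers for higher lipophilicity), compound 1 `CC#CCn1c(N2CCC[C@@H](N)C2)cc(=O)n(Cc2c(Br)c(Br)c(OC)c(OC)c2Br)c1=O` reads 4.04 and compound 2 `CC#CCn1c(N2CCC[C@@H](N)C2)cc(=O)n(Cc2cc(C)cc(C)c2)c1=O` reads 2.78 while compound 3 `CC#CCn1c(N2CCC[C@@H](N)C2)cc(=O)n(Cc2cc(F)cc(F)c2)c1=O` reads 2.12 as the lowest of the three. Compound 4 `N#Cc1ccc(F)cc1Cn1c(N2CCC[C@@H](N)C2)cc(=O)n(Cc2cc(F)cc(F)c2)c1=O` has no number yet. The change 2-cyano-5-fluorophenyl in place of prop-1-yn-1-yl on a saturated chain carbon bound to an aromatic nitrogen puts 2-cyano-5-fluorophenyl in place of prop-1-yn-1-yl on a saturated chain carbon bound to an aromatic nitrogen. For the measured compounds named here, the one measured single-place step a number 0.66 log units lower from compound 2 to compound 3 (beyond the scatter) concerns a different group, so it is a guide to size only, and no measured step touches the group exchanged here. A modest upward step a number 0.48 log units higher from compound 3 to compound 4 (beyond the scatter) is expected in this assay on this thin basis. Compound 4 is estimated at 2.6 with an expected range of 2 to 3.2 as the working figure.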

Compound 4, partition coefficient: 3.23
Compound 4: the middle estimate sits 0.63 log units below what was measured; measured number outside the range, above it.
By their numbers in this assay, from the lowest: compound 3; then compound 2; then compound 4; then compound 1.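

In this assay, 2-cyano-5-fluorophenyl in place of prop-1-yn-1-yl on a saturated chain carbon bound to an aromatic nitrogen gives a number 1.11 log units higher from compound 3 to compound 4 (beyond the scatter), a large change. This position, which holds but-2-yn-1-yl in compound 1, compound 2 and compound 3, therefore also moves the read-out. No measurement shown accounts for the size of this step.

Going by these compounds, how the step divides among the aromatic ring, the nitrile and the fluorine stays open. A plain benzyl group or a longer alkyne chain at this position would help separate these contributions.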